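Swapping Methyl for Fluoro on a Second Core

This account rests on a few compounds, and the source may have more. Where it says the series, first, only, none or still open, it means among the compounds named here.

Measured in a functional assay on MCF7 cells (Homo sapiens) for cytotoxicity, read by CCK-8 assay, with a stated time of 24 h; on this read-out lower numbers stand for stronger inhibition and higher numbers for weaker inhibition:
compound 1, `C/C(=C\c1cc(-c2ccc(C)cc2)co1)C(N)=O`: 1630 nM
compound 2, `C/C(=C\c1cc(-c2ccc(F)cc2)co1)C(N)=O`: 2210 nM
compound 3, `C/C(=C\c1cc(-c2ccc(C)cc2)cs1)C(N)=O`: > 50000 nM, which is a limit of the assay and not a number

Compound 1 and compound 2 share one core and differ only by fluoro in place of methyl on an aromatic carbon; this gives a 1.4-fold higher number from compound 1 to compound 2 (0.13 log units; within the scatter). Compound 3 carries a different core, and the difference between the two cores is not broken down here. For compound 3 the assay reports only (the limit of > 50000 nM in this assay, at which 1 of the 3 values shown sits). Compound 4, `C/C(=C\c1cc(-c2ccc(F)cc2)cs1)C(N)=O`, is not yet measured; it differs from compound 3 by fluoro in place of methyl on an aromatic carbon, the same change as between compound 1 and compound 2, in the same place. Because a 1.4-fold higher number from compound 1 to compound 2 (0.13 log units; within the scatter) lies within the scatter, the step from compound 3 to compound 4 in this assay is expected to be small, a step that the limit leaves unreadable from compound 3 to compound 4. Compound 4 is therefore expected near 60000 nM, somewhere between 20000 nM and 200000 nM, and most likely again reported only as a limit.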

Compound 4, half-maximal inhibitory concentration: 1440 nM
Estimate against measurement, compound 4: 42-fold (1.62 log units) above, outside the stated range (below it).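

In this assay, fluoro in place of methyl on the core of compound 3 gives an at least 34-fold lower number from compound 3 to compound 4 (1.54 log units; beyond the scatter). The size of this change therefore did not carry over from one core to the other: the same change on two cores in this assay, a 1.4-fold higher number (0.13 log units; within the scatter) from compound 1 to compound 2 and an at least 34-fold lower number (1.54 log units; beyond the scatter) from compound 3 to compound 4, at least 47-fold (1.67 log units) apart, beyond the scatter of two such steps The exact size of the new step stays unknown, and nothing here explains the difference between the cores, with compound 3 given only as a limit of the assay and not as a number: the limit of > 50000 nM in this assay, at which 1 of the 4 values shown sits.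

On these data alone, it remains open whether a chloro or methoxy group in the same place would behave like fluoro or like methyl on each core. Also open, as far as these compounds go, is whether other swaps depend on the core as strongly as this one.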